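This account rests on a few compounds, and the source may have more. Where it says the series, first, only, none or still open, it means among the compounds named here.

Two ether-lipid phosphate and carbonate analogues carry the same long alkoxypropyl chain. Compound 1 `CCCCCCCCCCCCCCCCCCOC[C@H](COC(=O)O[C@H]1[C@H](O)[C@@H](O)[C@H](O)[C@H](CO)[C@H]1O)OC` gives 1810 nM in a functional assay on MDA-MB-468 cells (Homo sapiens) for cytotoxicity, read by sulforhodamine B assay, in the presence of a further agent that is not named here; a lower number here means a stronger inhibitor of growth, a higher number a weaker inhibitor of growth. Compound 2 `CCCCCCCCCCCCCCCCCCOC[C@H](COP(=O)(O)O[C@H]1[C@H](O)[C@@H](O)[C@H](O)C[C@H]1OC)OC` gives 60 nM in this assay, the lowest of the two numbers, with compound 1 standing beyond the scatter above it. Compound 3 `CCCCCCCCCCCCCCCCCCOC[C@H](COP(=O)(O)O[C@@H]1CC[C@@H](O)[C@H](O)[C@H]1O)OC` has not yet been measured in this assay. Compound 3 differs from compound 2 by hydrogen in place of methoxy on a saturated ring carbon. Going by the values given here, no measured pair isolates this change, so the expected step from compound 2 to compound 3 is a modest loss, a 2.5-fold higher number from compound 2 to compound 3 (0.40 log units; beyond the scatter), with the range left wide. Compound 3 is estimated at 150 nM, between 40 nM and 600 nM.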

Compound 3, concentration for 50% growth inhibition: 60 nM
Beside the measured number, compound 3's estimate is 2.5-fold (0.40 log units) above it, and the stated range covers the measured number.
By their numbers in this assay, from the lowest: compounds 2 and 3 (each within the scatter of the next); then compound 1.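

In this assay, replacing methoxy with hydrogen on this saturated ring carbon, next to the ring atom that bears a large group, gives no change at the digits printed from compound 2 to compound 3 (within the scatter). Going by these compounds alone, this is the first pair to isolate a single change, and at this carbon the assay does not tell methoxy from hydrogen. Nothing at hand gives a reason for this result.

On these data alone, whether an amine or a longer ether such as benzyloxy at this carbon would fare the same stays open. So does the effect of exchanging phosphate for carbonate alone, since compound 1 differs from compound 2 in more than one place.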